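Compound 4: a carbamoyl in place of an ethyl

The source may hold more compounds than are shown below. What is called first, only, known or untested is meant among the compounds shown, and "the series" means these compounds.

Measured so far:
compound 1, `c1cnc(CN(CCCN2CCNCC2)[C@H]2CCCc3cccnc32)nc1`, 100%
compound 2, `c1cnc2c(c1)CCC[C@@H]2N(CCCN1CCNCC1)Cc1nc2ccccc2s1`, 50%
compound 3, `CCN1CCN(CCCN(C[C@H]2Cc3ccccc3CN2)[C@H]2CCCc3cccnc32)CC1`, 59%

In an ADME assay on microsomes from liver (Homo sapiens) for metabolic stability, read by LC-MS, with a stated time of 10 min, tested at 0.5 uM (a lower number here means that less of the compound is left, a higher number that more of the compound is left), compound 3 stands second highest of the three numbers; its nearest neighbour is compound 2, within the scatter, while compound 1 lies beyond the scatter above it. Compound 4, `NC(=O)N1CCN(CCCN(C[C@H]2Cc3ccccc3CN2)[C@H]2CCCc3cccnc32)CC1`, differs from compound 3 by carbamoyl in place of ethyl on an amine nitrogen in a ring. Among the compounds with values here, the only measured step, a number 50 percentage points lower from compound 1 to compound 2 (beyond the scatter), concerns a different position and a different kind of group, so it does not bear directly on this change; no measured pair shows what a carbamoyl in place of an ethyl does here. With nothing to anchor a direction, the expected change is modest: a number 11 percentage points higher from compound 3 to compound 4 (beyond the scatter). Compound 4 is therefore estimated at 70%, within a range from 45% to 95%.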

Compound 4, percent of the compound remaining: 79%
Compound 4: the middle estimate sits 9 percentage points below what was measured, and the stated range covers the measured number.
By their numbers in this assay, from the lowest: compounds 2 and 3 (each within the scatter of the next); then compound 4; then compound 1.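

In this assay the amine nitrogen in a ring proves to be a place where the group matters: carbamoyl in place of ethyl gives a clear change (a number 20 percentage points higher from compound 3 to compound 4 (beyond the scatter)). Within the data shown here, the earlier step concerned a different place, so this is the first reading at this position. Nothing available explains why the number moves.

As far as these compounds go, it remains open whether other groups on this nitrogen, such as an acetyl or a methyl, would behave like carbamoyl or like ethyl. From the compounds shown here alone, the same carbamoyl change on the other cores also remains open.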